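Metabolic stability notes: carboxyphenyl ether series, step to compound 3

A few compounds are considered here, and "the series" means these few. Any claim that something is new, unique, unknown or untested is made for them only; others in the source may bear on it.

Measured so far:
compound 1, `Cc1c(OCCCCOc2cccc(C(=O)O)c2)ccc(C(=O)CC(C)C)c1O`: 51%
compound 2, `Cc1c(OCCCCOc2ccc(C(=O)O)c(Cl)c2)ccc(C(=O)CC2CCCC2)c1O`: 67%

In an ADME assay (liver) for metabolic stability, with Liver microsome (Rattus norvegicus) as the target, read by LC-MS, using microsomes and NADPH, with stated times of 5 min and 60 min, tested at 4 uM (a higher number here means that more of the compound is left, a lower number that less of the compound is left), compound 2 gives 67%. In this assay compound 1 gives 51%. Compound 2 stands highest of the two numbers; the gap to compound 1 lies beyond the scatter. Within the data shown here, the two compounds differ in more than one place, so no single step is attributed to either change.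

Compound 3, `Cc1c(OCCCCOc2cccc(C(=O)O)c2)ccc(C(=O)CC2CCCC2)c1O`, has not yet been measured. Relative to compound 2 the change is 3-carboxyphenyl in place of 4-carboxy-3-chlorophenyl on an oxygen on a saturated carbon. Compound 1 carries the same 3-carboxyphenyl and its value in this assay sits below that of compound 2, so a step downward in this assay is expected, near the edge of the scatter. For compound 3 the estimate in this assay is 56%, range 40% to 70%. The step that this estimate means is a number 11 percentage points lower from compound 2 to compound 3 (beyond the scatter), expected but uncertain, since compound 1 also differs at the ketone side chain.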

Compound 3, percent of the compound remaining: 55%
Compound 3: the middle estimate sits 1 percentage points above what was measured; the range from low to high includes it.
By their numbers in this assay, from the lowest: compounds 1 and 3 (each within the scatter of the next); then compound 2.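

In this assay, among these compounds, 3-carboxyphenyl in place of 4-carboxy-3-chlorophenyl on an oxygen on a saturated carbon gives a number 12 percentage points lower from compound 2 to compound 3 (beyond the scatter), the first reading of this change with the rest of the structure held constant. Cyclopentyl in place of isopropyl on a saturated chain carbon bound to a carbonyl carbon gives a number 4 percentage points higher from compound 1 to compound 3 (within the scatter), so of these two single-place changes only the one at the aryl ether has a step beyond the scatter. No supporting measurement bears on what lies behind either step.

The aryl change alters the chlorine and the carboxy placement together, so the step cannot be assigned to either one, and 4-carboxyphenyl would separate them. As far as these compounds go, how a fluorine in place of the chlorine or an amide in place of the carboxylic acid would stand in this assay also remains open.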